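A Sulfamoylphenyl Amide Set Against Its Difluorophenyl Counterpart

The compounds below may be only part of what the source reports. "The series", "measured", "known", "first", "only" and "open" are said of these compounds alone.

Three amides share one core. In an ADME assay on LLC-MK2 cells (Macaca mulatta) for cytotoxicity, read by spectrophotometry and crystal violet staining, with a stated time of 4 days (on this read-out higher numbers stand for lower toxicity in this test and lower numbers for higher toxicity in this test), compound 1 `CC(C)n1ncc2c(C(=O)Nc3ccccn3)cc(-c3ccccc3)nc21` gives 12500 nM and compound 2 `CC(C)n1ncc2c(C(=O)N3CCc4cccnc43)cc(-c3cccs3)nc21` gives 50000 nM. Compound 3 `CC(C)n1ncc2c(C(=O)Nc3ccc(F)c(F)c3)cc(-c3cccs3)nc21` reaches only the limit of this assay, > 200000 nM. Among the compounds with values here, the step of an at least 4.0-fold higher number from compound 2 to compound 3 (0.60 log units; beyond the scatter) is the only measured change, and it ends at the limit of > 200000 nM in this assay, at which 1 of the 3 values shown sits, so compound 3 stands at the limit rather than at a number. Compound 4 `CC(C)n1ncc2c(C(=O)Nc3cccc(S(N)(=O)=O)c3)cc(-c3cccs3)nc21` differs from compound 3 in one place: 3-sulfamoylphenyl in place of 3,4-difluorophenyl on an amide-type nitrogen. Within the data shown here, no measured step covers this exchange; the step from compound 2 to compound 3 shows only that compound 3 reached the limit. A step of about a number no higher from compound 3 to compound 4 (the limit leaves the size open) is expected, most likely none beyond the scatter. Compound 4 is therefore estimated at 200000 nM, within 60000 nM to 400000 nM, with a limit again likely.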

Compound 4, half-maximal cytotoxic concentration: 25000 nM
Compound 4: middle estimate off by 8.0-fold (0.90 log units), on the high side; the whole stated range lies above it.
By their numbers in this assay, from the lowest: compounds 1, 4 and 2 (each within the scatter of the next, the first and the last beyond it). At a limit, above all of these: compound 3.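

On this amide-type nitrogen, keeping the six-membered aromatic ring of carbon and changing only what it carries is enough to move the read-out in this assay: 3-sulfamoylphenyl in place of 3,4-difluorophenyl gives an at least 8.0-fold lower number from compound 3 to compound 4 (0.90 log units; beyond the scatter). The earlier step had exchanged the ring system itself, so it could not show this. Compound 3 stands at a limit and not at a number, so the step gives only a lower bound on the change: the limit of > 200000 nM in this assay, at which 1 of the 4 values shown sits.

As far as these compounds go, it remains open whether the sulfonamide as a whole accounts for the change. A carboxylic acid, an amine or a methylsulfonyl group in its place on the phenyl ring would test that.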